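Fluoro in Place of Chloro: Small Change, Small Step Expected

The compounds below may be only part of what the source reports. "The series", "measured", "known", "first", "only" and "open" are said of these compounds alone.

Measured so far:
Compound 1, `N=C(N)c1ccc(-c2ccc(-c3ccc(Cl)cc3)s2)s1`, 1750 nM
Compound 2, `N=C(N)c1ccc(-c2ccc(-c3ccc4ccccc4c3)s2)s1`, 1960 nM
Compound 3, `N=C(N)c1ccc(-c2ccc(-c3ccc(F)cc3)o2)o1`, 1430 nM

In a functional assay on UO-31 cells (Homo sapiens) for inhibition, read by sulforhodamine B assay, with a stated time of 48 h (a lower number here means a stronger inhibitor of growth, a higher number a weaker inhibitor of growth), compound 1 gives 1750 nM, the second highest of the three numbers. Its nearest neighbour is compound 2, which in this assay gives 1960 nM, a gap within the usual scatter, and its furthest is compound 3, which gives 1430 nM, also within the scatter. Among the measured compounds shown here, the three measured compounds thus sit together, with no step among them that separates one from another.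

Compound 4, `N=C(N)c1ccc(-c2ccc(-c3ccc(F)cc3)s2)s1`, has not yet been measured. It differs from compound 1 in one place: fluoro in place of chloro on an aromatic carbon. For the measured compounds named here, no measured pair shows this exchange, so the size of the step has no direct precedent here. Compound 3 carries the same fluoro group on a different core and lies within the scatter of compound 1, which gives 1750 nM; that gives no reason to expect a shift in either direction.

Compound 4 is therefore expected to give about 1700 nM, between 750 nM and 3800 nM, meaning an expected step of a 1.0-fold lower number from compound 1 to compound 4 (0.01 log units; within the scatter), none beyond the scatter.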

Compound 4, concentration for 50% growth inhibition: 1770 nM
Compound 4: the middle estimate sits 1.0-fold (0.02 log units) below what was measured; low and high end bracket the measured number.
By their numbers in this assay, from the lowest: compounds 3, 1, 4 and 2 (each within the scatter of the next).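

In this assay, fluoro in place of chloro on an aromatic carbon, para to a large group, gives a 1.0-fold higher number from compound 1 to compound 4 (0.00 log units; within the scatter), so the two groups cannot be told apart at this place on the shared core. The earlier compounds shown here could only hint at this across different cores, whereas this pair reads the exchange directly, with everything else in the structure held the same. Nothing available here bears on why the two groups read alike.

The compounds shown do not tell whether an amine, a methoxy group or a carboxylic acid at this place would give a number beyond the scatter of compound 1. Nor do they tell whether chloro in place of fluoro on the core of compound 3 would read the same way.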